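A few compounds are considered here, and "the series" means these few. Any claim that something is new, unique, unknown or untested is made for them only; others in the source may bear on it.

Measured compounds:
compound 1 `Oc1ccc(-c2cc(-c3cccs3)cc(-c3cccc(O)c3)n2)cc1` — 1770 nM
compound 2 `Oc1ccc(-c2cc(-c3cccs3)cc(-c3ccc(O)cc3)n2)cc1` — > 50000 nM
compound 3 `Oc1cccc(-c2cc(-c3ccccn3)cc(-c3cccc(O)c3)n2)c1` — 3510 nM

In a functional assay on HCT-15 cells (Homo sapiens) for cytotoxicity, read by CCK-8 assay (on this read-out lower numbers stand for stronger inhibition and higher numbers for weaker inhibition), compound 1 gives 1770 nM. Compound 2 reaches only the limit of this assay, > 50000 nM, which is a limit and not a number (the limit of > 50000 nM in this assay, at which 1 of the 3 values shown sits). The step of an at least 28-fold higher number from compound 1 to compound 2 (1.45 log units; beyond the scatter) comes from the change (4-hydroxyphenyl in place of 3-hydroxyphenyl on an aromatic carbon). Compound 3 gives 3510 nM in this assay; how its core differs from that of compound 1 is not broken down here. Compound 4 `Oc1ccc(-c2cc(-c3ccccn3)cc(-c3cccc(O)c3)n2)cc1` has not yet been measured. It is reached from compound 3 by 4-hydroxyphenyl in place of 3-hydroxyphenyl on an aromatic carbon, the same kind of change as that from compound 1 to compound 2, though here the place is meta to a 3-hydroxyphenyl group and to a pyridin-2-yl group rather than to a 4-hydroxyphenyl group and a thiophen-2-yl group. Resting on the step of an at least 28-fold higher number from compound 1 to compound 2 (1.45 log units; beyond the scatter), compound 4 is expected to show a much higher number in this assay, perhaps again only the limit. The expected step is a 20-fold higher number from compound 3 to compound 4 (1.30 log units; beyond the scatter). Compound 4 is estimated at 70000 nM, between 15000 nM and 300000 nM.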

Compound 4, half-maximal inhibitory concentration: > 50000 nM
Compound 4 gave a limit, no number; the forecaster's own chance of this, stated with the estimate: 70%; the middle value lies beyond the limit too.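

In this assay compound 4 gives > 50000 nM, which is a limit and not a number. Placing 4-hydroxyphenyl where 3-hydroxyphenyl stood gives an at least 14-fold higher number from compound 3 to compound 4 (1.15 log units; beyond the scatter). The change thus raises the number strongly on both cores, so the direction of the change carries over from one core to the other: the same change on two cores in this assay, an at least 28-fold higher number (1.45 log units; beyond the scatter) from compound 1 to compound 2 and an at least 14-fold higher number (1.15 log units; beyond the scatter) from compound 3 to compound 4; the limit leaves it open whether they differ How large the step really is on either core stays unknown, as compound 2 and compound 4 give only limits: the limit of > 50000 nM in this assay, at which 2 of the 4 values shown sit.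

Pyridin-2-yl in place of thiophen-2-yl gives an at least 28-fold higher number from compound 1 to compound 4 (1.45 log units; beyond the scatter), and this rests on a single pair. Going by these compounds, it remains open whether an amine or a methoxy group in place of the hydroxyl of the 4-hydroxyphenyl group would also leave the value at the limit.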